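Swapping a nitro for a bromo on a shared chalcone core

This account rests on a few compounds, and the source may have more. Where it says the series, first, only, none or still open, it means among the compounds named here.

Of the compounds shown here, three built on one shared core have been measured in a functional assay on MCF7 cells (Homo sapiens) for cytotoxicity, read by MTT assay, with a stated time of 68 h; on this read-out lower numbers stand for stronger inhibition and higher numbers for weaker inhibition. Compound 1 `O=C(/C=C/c1cccc(OCc2ccccc2)c1)c1ccc([N+](=O)[O-])cc1` gives 17500 nM, the second highest of the three numbers. Compound 2 `O=C(/C=C/c1cccc(OCc2ccccc2)c1)c1ccc(O)cc1` gives 2800 nM, and compound 3 `O=C(/C=C/c1cccc(OCc2ccccc2)c1)c1ccc(Cl)cc1` gives 24800 nM. The steps between them show a 6.3-fold lower number from compound 1 to compound 2 (0.80 log units; beyond the scatter), a 1.4-fold higher number from compound 1 to compound 3 (0.15 log units; within the scatter) and an 8.9-fold higher number from compound 2 to compound 3 (0.95 log units; beyond the scatter).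

Compound 4 `O=C(/C=C/c1cccc(OCc2ccccc2)c1)c1cccc(Br)c1` is the next member: it differs from compound 1 by 3-bromophenyl in place of 4-nitrophenyl on a carbonyl carbon. The step that bears most directly on this change is the one from nitro to chloro, since compound 4 also carries a halogen-bearing ring, and that step was a 1.4-fold higher number from compound 1 to compound 3 (0.15 log units; within the scatter). The hydroxy step ran the other way, but no hydroxy enters here. The expectation for compound 4 in this assay is therefore no step beyond the scatter, so that the change amounts to a 1.3-fold higher number from compound 1 to compound 4 (0.10 log units; within the scatter). Compound 4 is estimated at 22000 nM, with a range from 8000 nM to 60000 nM.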

Compound 4, half-maximal inhibitory concentration: 7900 nM
Compound 4: middle estimate off by 2.8-fold (0.44 log units), on the high side, outside the stated range (below it).
By their numbers in this assay, from the lowest: compound 2; then compound 4; then compounds 1 and 3 (each within the scatter of the next).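

Until now, only the hydroxy group had moved the number on this carbonyl-bound ring beyond the scatter, yet 3-bromophenyl also does so, giving (a 2.2-fold lower number from compound 1 to compound 4 (0.35 log units; beyond the scatter)) and (a 3.1-fold lower number from compound 3 to compound 4 (0.50 log units; beyond the scatter)), so the two halogen-bearing rings are not interchangeable here. The 4-hydroxyphenyl ring still holds the advantage, with (a 2.8-fold higher number from compound 2 to compound 4 (0.45 log units; beyond the scatter)), which places the bromo compound in an intermediate position rather than level with the nitro and chloro compounds. No measurement shown here explains these differences.

Because the change from compound 3 to compound 4 swaps both the halogen and its place on the ring, the compounds shown cannot separate those two effects. A 4-bromophenyl or 3-chlorophenyl ring would pull them apart, while an amine or a carboxylic acid on this ring remains an open question.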